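From compound 1 to compound 3: a fluorobenzyl ester

A few compounds are considered here, and "the series" means these few. Any claim that something is new, unique, unknown or untested is made for them only; others in the source may bear on it.

For the measured compounds named here, compound 1 `CCOC(=O)CN(C)C(=O)c1ccc(C(CC)(CC)c2ccc(OCC(O)C(C)(C)C)c(C)c2)n1CC` gives 10100 nM in an ADME assay on L02 cells (Homo sapiens) for cytotoxicity, read by MTT assay, with a stated time of 48 h (a higher number here means a weaker inhibitor, a lower number a stronger inhibitor), the highest of the two numbers known so far. Going by the values given here, compound 2 `CCn1c(C(=O)NCCN)ccc1C(CC)(CC)c1ccc(OCC(O)C(C)(C)C)c(C)c1` gives 2400 nM in this assay, and a 4.2-fold lower number from compound 1 to compound 2 (0.62 log units; beyond the scatter) is the only measured step. Compound 3 `CCn1c(C(=O)OCc2ccc(F)cc2)ccc1C(CC)(CC)c1ccc(OCC(O)C(C)(C)C)c(C)c1` differs from compound 1 by (4-fluorobenzyl)oxy in place of ((ethoxycarbonyl)methyl)(methyl)amino on a carbonyl carbon. Among the compounds with values here, no measured step shares this change; the step that touched the same carbonyl carbon brought in a different group, so it guides only loosely. A modest lowering at most is expected: a 1.7-fold lower number from compound 1 to compound 3 (0.23 log units; within the scatter). Compound 3 is estimated at 6000 nM, with a range from 2000 nM to 18000 nM.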

Compound 3, half-maximal inhibitory concentration: 14900 nM
For compound 3 the middle estimate is 2.5-fold (0.40 log units) below the measured one, and the stated range covers the measured number.
By their numbers in this assay, from the lowest: compound 2; then compounds 1 and 3 (each within the scatter of the next).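

In this assay, (4-fluorobenzyl)oxy in place of ((ethoxycarbonyl)methyl)(methyl)amino on the carbonyl carbon gives a 1.5-fold higher number from compound 1 to compound 3 (0.17 log units; within the scatter) and so does not separate these two groups. Set against the (2-aminoethyl)amino group, the same (4-fluorobenzyl)oxy gives a 6.2-fold higher number from compound 2 to compound 3 (0.79 log units; beyond the scatter) and thus leaves compound 2 alone with the lowest number of the three. No measurement at hand explains this difference. Still open, going by these compounds, is whether a carboxylic acid or a longer aminoalkyl chain on this carbonyl carbon would read like compound 2 or like compound 3.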